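Dropping the Cyano Group: What to Expect for Compound 4

The compounds below may be only part of what the source reports. "The series", "measured", "known", "first", "only" and "open" are said of these compounds alone.

Of the compounds shown here, three sharing one core have been measured in an in vitro functional assay on cells for agonist activity at Bombesin receptor subtype-3 (Mus musculus), read by luminescence and calcium flux; a higher number here means that more compound is needed for the effect, a lower number that less compound is needed. Compound 1 `CCCCc1cnc(C(CC)Cc2ccc(-c3ccccc3C(=O)O)cc2)[nH]1` gives 340 nM in this assay. Compound 3 `CCCCc1cnc(C(Cc2ccc(-c3ccccc3C(=O)O)cc2)C(C)C)[nH]1` differs from compound 1 by a methyl in place of hydrogen on a saturated chain carbon bound to two saturated chain carbons, and in this assay compound 3 gives 2240 nM, so that the step is a 6.6-fold higher number from compound 1 to compound 3 (0.82 log units; beyond the scatter). Compound 2 `N#Cc1ccccc1Cc1cnc(CCc2ccc(-c3ccccc3C(=O)O)cc2)[nH]1` gives 642 nM in this assay, the second highest of the three numbers: its gap to compound 1 lies within the scatter, while its gap to compound 3 lies beyond it.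

Compound 4 `O=C(O)c1ccccc1-c1ccc(CCc2ncc(Cc3ccccc3)[nH]2)cc1` has not been measured. It differs from compound 2 in a single place: hydrogen in place of cyano on an aromatic carbon. Among the measured compounds shown here, no measured step touches this part of the molecule. For the measured compounds named here, the one known step, from compound 1 to compound 3, alters a saturated chain carbon and says nothing about the cyano group. With no guidance from the data, no change beyond the scatter is expected. The step expected in this assay is a 1.2-fold higher number from compound 2 to compound 4 (0.10 log units; within the scatter), meaning none beyond the scatter. Compound 4 is therefore estimated at 800 nM in this assay, within a range from 250 nM to 2600 nM.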

Compound 4, half-maximal effective concentration: 11 nM
Compound 4: the middle estimate sits 73-fold (1.86 log units) above what was measured; the whole stated range lies above it.
By their numbers in this assay, from the lowest: compound 4; then compounds 1 and 2 (each within the scatter of the next); then compound 3.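

Replacing 2-cyanobenzyl with benzyl gives a 58-fold lower number from compound 2 to compound 4 (1.77 log units; beyond the scatter) in this assay, so less compound is needed for the effect once the nitrile is gone. Among the compounds shown here, the earlier compounds held no pair differing at this aromatic carbon, and this step is the first sign that the position matters: the group that leaves has only 2 heavy atoms, yet the number changes far beyond the scatter. Nothing in the data shown explains the size of this step.

The compounds shown offer only a nitrile and a hydrogen at this place, so it remains open whether the nitrile is a special case or whether other groups here, such as a methyl, a fluorine or a methoxy group, would also give a higher number than hydrogen does. Also open, going by these compounds, is whether the same replacement would have a similar effect in compounds with a different chain on the carbon attached to the shared core, such as the branched chains of compound 1 and compound 3.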